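From Cyclohexyl Anilide to Phenylsulfonyl Anilide

The compounds below may be only part of what the source reports. "The series", "measured", "known", "first", "only" and "open" are said of these compounds alone.

Compound 1 `COC(=O)c1cc(=O)c2c(OC)cc(OC)cc2[nH]1` is the smallest member of this small set. In a functional assay on KOPN-8 cells (Homo sapiens) for antiproliferative activity, with a stated time of 72 h (on this read-out higher numbers stand for an effect only at larger amounts of compound and lower numbers for an effect already at smaller amounts), compound 1 reaches only a limit, > 34400 nM, which is a bound of the measurement and not a number. Compound 2 `COc1cc(OC)c2c(=O)cc(C(=O)Nc3ccc(C4CCCCC4)cc3)[nH]c2c1` extends the shared core into an anilide that carries a cyclohexyl group; in this assay compound 2 gives 18400 nM. Among the values shown, compound 2 alone provides an actual number. The remaining entry, that of compound 1, is a limit (the limit of > 34400 nM in this assay, at which 1 of the 2 values shown sits). Among the compounds with values here, no step between two measured compounds that differ in a single place is available, so the size of a change cannot be read from measured pairs. Compound 3 `COc1cc(OC)c2c(=O)cc(C(=O)Nc3ccc(S(=O)(=O)c4ccccc4)cc3)[nH]c2c1` differs from compound 2 by phenylsulfonyl in place of cyclohexyl on an aromatic carbon. Within the data shown here, with no measured step to lean on, compound 3 is expected to remain close to compound 2, the step of a 1.1-fold higher number from compound 2 to compound 3 (0.04 log units; within the scatter) being expected to stay within the usual scatter. In this assay compound 3 is therefore estimated at 20000 nM, with a range from 6000 nM to 60000 nM.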

Compound 3, half-maximal effective concentration: > 70600 nM
Compound 3: a limit, no number; the forecaster's own chance of this, stated with the estimate: 35%; middle value at least 3.5-fold (0.54 log units) from the limit.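

Within the data shown here, this is the first single change that can be read in this assay: phenylsulfonyl in place of cyclohexyl on an aromatic carbon, para to a large group, gives an at least 3.8-fold higher number from compound 2 to compound 3 (0.58 log units; beyond the scatter). Compound 3 reaches only a limit, not a number: the limit of > 70600 nM in this assay, at which 1 of the 3 values shown sits. The group on this carbon of the anilide therefore matters, since this exchange, which replaces a non-aromatic ring of carbon only with an aromatic one and brings in hydrogen-bond acceptors, shifts the effect beyond the usual scatter towards larger amounts of compound, leaving compound 2 as the only one of the set with an actual number.

With this single step, the compounds shown cannot separate the part played by the aromatic ring from that of the sulfonyl link, and the full size of the step remains unknown. They also leave open how an amine, a carboxylic acid or a longer alkyl chain on this carbon would read in this assay, and whether any group here could bring the number below that of compound 2.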